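From Aryl Ester to Bromobenzyl Ether on a Shared Core

The source may report more compounds than this note shows. Statements on the series, on what has been measured and on what is new or still open speak of the compounds shown alone.

Compound 1 `COc1cccc(C(=O)Oc2ccc3c(=O)c(-c4cc(OC)c(OC)cc4OC)coc3c2)c1` gives > 10000 nM in a functional assay on U-251 cells (Homo sapiens) for antiproliferative activity, read by MTT assay, with a stated time of 24 h; on this read-out higher numbers stand for weaker inhibition and lower numbers for stronger inhibition.
Compound 2 `COc1cc(OC)c(-c2coc3cc(OCc4ccc([N+](=O)[O-])cc4)ccc3c2=O)cc1OC` gives 9400 nM in this assay.
Compound 3 `COc1cc(OC)c(-c2coc3cc(OCc4ccccc4C#N)ccc3c2=O)cc1OC` gives 980 nM in this assay.

Compound 1 stands only at a limit of this assay, not at a number, as the value the limit of > 10000 nM in this assay, at which 1 of the 3 values shown sits, shows. Compound 4 `COc1cc(OC)c(-c2coc3cc(OCc4cccc(Br)c4)ccc3c2=O)cc1OC` differs from compound 1 by 3-bromobenzyl in place of (3-methoxyphenyl)carbonyl on an oxygen on an aromatic ring. Among the compounds with values here, two measured steps bear on this change, since both also replace the ester group on that oxygen with a benzyl group. The step of an at least 1.0-fold lower number from compound 1 to compound 2 (0.02 log units; that floor lies within the scatter) stayed within the scatter, while the step of an at least 10-fold lower number from compound 1 to compound 3 (1.00 log units; beyond the scatter) went well beyond it; between the two benzyl compounds, the step of a 9.6-fold lower number from compound 2 to compound 3 (0.98 log units; beyond the scatter) separates them clearly. A third benzyl variant such as compound 4 is therefore expected to land somewhere between these two outcomes, most likely stronger than compound 1 but without the full gain seen for compound 3. Compound 4 is thus expected to show a step of an at least 2.8-fold lower number from compound 1 to compound 4 (0.45 log units; beyond the scatter) in this assay. For compound 4 the estimate is 3500 nM, with a range from 900 nM to 12000 nM.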

Compound 4, half-maximal inhibitory concentration: > 10000 nM
Compound 4: a limit, no number; the forecaster's own chance of this, stated with the estimate: 25%; middle value at least 2.8-fold (0.45 log units) from the limit.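

In this assay compound 4 gives > 10000 nM, which is a limit and not a number. This shows that a benzyl group on this oxygen does not carry the gain by itself, and that the group it bears matters: 3-bromophenyl in place of 2-cyanophenyl gives an at least 10-fold higher number from compound 3 to compound 4 (1.00 log units; beyond the scatter), while 3-bromophenyl in place of 4-nitrophenyl gives an at least 1.0-fold higher number from compound 2 to compound 4 (0.02 log units; that floor lies within the scatter), so among these benzyl ethers compound 3 alone stands apart. The step between compound 1 and compound 4 cannot be read, since both values are limits: the limit of > 10000 nM in this assay, at which 2 of the 4 values shown sit.

As far as these compounds go, it remains open whether the gain in compound 3 belongs to the nitrile itself or to where it sits on the benzyl group. From the compounds shown here alone, how a benzyl group carrying an amine or a carboxylic acid would read also stays open.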